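Aryl amide variation on a shared thioacetamide-linked core

This account rests on a few compounds, and the source may have more. Where it says the series, first, only, none or still open, it means among the compounds named here.

Three anilide analogues of one core have been measured in an assay on isolated protein for inhibition of Ectonucleotide pyrophosphatase/phosphodiesterase family member 1 (Homo sapiens), tested at 10 uM; a higher number here means more inhibition at the concentration tested (going by the name of the read-out), a lower number less inhibition. Compound 1 `O=C(CSc1nc2cccnc2[nH]1)Nc1ccc(Cl)c(Cl)c1` gives 10%. Compound 2 `O=C(CSc1nc2cccnc2[nH]1)Nc1cccc(Br)c1` gives 23%. Compound 3 `CN(C)c1ccc(NC(=O)CSc2nc3cccnc3[nH]2)cc1` gives 23%, level with compound 2 at the digits reported and, together with it, the highest of the three numbers; the gap to compound 1, the furthest of the set, is beyond the scatter, while the difference to compound 2 is within it, so no order between compound 2 and compound 3 can be claimed.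

The next analogue, compound 4 `O=C(CSc1nc2cccnc2[nH]1)Nc1ccc(Cl)cc1`, is not yet measured. It differs from compound 3 in one place: chloro in place of dimethylamino on an aromatic carbon. For the measured compounds named here, no measured pair of this series isolates that change, so the expectation rests on the halogen-bearing anilides already in hand. Compound 2 reaches the same number as compound 3, whereas compound 1, also chloro-bearing, sits lower at 10%. On this basis the step of a number 8 percentage points lower from compound 3 to compound 4 (within the scatter) is expected to be small and downward, likely not beyond the scatter. Compound 4 is therefore estimated at 15%, with a range from 2% to 30%.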

Compound 4, a percentage reported as inhibition, at one concentration (the size of the read-out at that concentration, not a potency): 17%
The estimate for compound 4 lay 2 percentage points below the measured number; low and high end bracket the measured number.
By their numbers in this assay, from the lowest: compounds 1, 4, 2 and 3 (each within the scatter of the next, the first and the last beyond it).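

In this assay, chloro in place of dimethylamino on an aromatic carbon, para to a large group, gives a number 6 percentage points lower from compound 3 to compound 4 (within the scatter), so this exchange at this position cannot be told apart from repeat scatter. The two halogen comparisons read the same way: 4-chlorophenyl in place of 3-bromophenyl on an amide-type nitrogen gives a number 6 percentage points lower from compound 2 to compound 4 (within the scatter), and hydrogen in place of chloro on an aromatic carbon gives a number 7 percentage points higher from compound 1 to compound 4 (within the scatter). Compound 4 therefore adds three single-place comparisons to a series that previously had none, yet none of them resolves an effect of the change involved, and no measurement at hand bears on a cause for these numbers.

Still open, as far as these compounds go, is what a primary amine, a carboxylic acid or a methoxy group on this same aromatic carbon would give in this assay, and whether any of them would differ from compound 4 by more than the scatter. Also open is whether a longer chain in place of the thioacetamide link would move the number, since all the compounds shown keep that link unchanged.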